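Adding an amino link to a sulfonyl-bound fluorophenyl group

The compounds below may be only part of what the source reports. "The series", "measured", "known", "first", "only" and "open" are said of these compounds alone.

Compound 1 `Cn1c(=O)c(S(=O)(=O)c2ccc(C(=O)O)cc2)cc2cnc(Nc3ccc4[nH]ccc4c3)nc21`: 5000 nM
Compound 2 `Cn1c(=O)c(C(=O)Nc2ccc(F)cc2)cc2cnc(Nc3ccc4[nH]ccc4c3)nc21`: 5000 nM
Compound 3 `Cn1c(=O)c(S(=O)(=O)c2ccc(F)cc2)cc2cnc(Nc3ccc4[nH]ccc4c3)nc21`: 200 nM

These values come from a functional assay on K562 cells (Homo sapiens) for inhibition, read by trypan blue exclusion, with a stated time of 72 h; a lower number here means a stronger inhibitor, a higher number a weaker inhibitor. Compound 3 has the lowest number of the three, and its steps to both others lie beyond the scatter, so it is the strongest inhibitor of this small set.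

Compound 4 `Cn1c(=O)c(S(=O)(=O)Nc2ccc(F)cc2)cc2cnc(Nc3ccc4[nH]ccc4c3)nc21` has not yet been measured. It carries (4-fluorophenyl)amino in place of 4-fluorophenyl on a sulfonyl sulfur.

The closest evidence is a 25-fold lower number from compound 2 to compound 3 (1.40 log units; beyond the scatter), a large step, in which the group at the higher number also holds a nitrogen alongside its fluorinated ring. The other measured step, a 25-fold lower number from compound 1 to compound 3 (1.40 log units; beyond the scatter), is also large and shows that changes in this part of the molecule can shift the number strongly. Among the compounds with values here, no measured compound keeps the sulfonyl group and adds the amino link, so the size remains uncertain.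

A rise in the number in this assay is expected, probably smaller than those steps. The expected change is a 5.0-fold higher number from compound 3 to compound 4 (0.70 log units; beyond the scatter). Compound 4 is estimated at 1000 nM, with an expected range of 250 nM to 5000 nM.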

Compound 4, half-maximal inhibitory concentration: 5000 nM
Beside the measured number, compound 4's estimate is 5.0-fold (0.70 log units) below it; the measured number falls inside the stated range.
By their numbers in this assay, from the lowest: compound 3; then compounds 1, 2 and 4 (each within the scatter of the next).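

In this assay, placing an amino link on the sulfonyl sulfur undoes the gain seen with the directly bound 4-fluorophenyl, giving a 25-fold higher number from compound 3 to compound 4 (1.40 log units; beyond the scatter) as a large step. The new sulfamoyl compound also sits level with the two earlier weak compounds, with no change at the digits printed from compound 2 to compound 4 (within the scatter) for the carbamoyl partner and no change at the digits printed from compound 1 to compound 4 (within the scatter) for the 4-carboxyphenyl partner, so among these four compounds only compound 3 stands apart. No measurement shown here explains why the extra nitrogen has this effect. As far as these compounds go, whether the amino hydrogen or simply the added link atom matters remains open. A (4-fluorobenzyl)sulfonyl group, with a methylene in place of the nitrogen, or an N-methyl-(4-fluorophenyl)sulfamoyl group, without the amino hydrogen, would help to separate those two readings.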